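This account rests on a few compounds, and the source may have more. Where it says the series, first, only, none or still open, it means among the compounds named here.

Measured compounds:
- compound 1 `COc1cc(Cl)cc(-c2nn(-c3cccc(NC(=O)Nc4ccc(Cl)c(Cl)c4)c3)cc2-c2ccncc2)c1`, giving 62% in a functional assay on HT-29 cells (Homo sapiens) for inhibition, read by sulforhodamine B assay, with a stated time of 48 h, tested at 1 uM; on this read-out higher numbers stand for a weaker effect at the one concentration tested and lower numbers for a stronger effect
- compound 2 `COc1cc(Cl)cc(-c2nn(-c3cccc(NC(=O)Nc4cccc(C(F)(F)F)c4)c3)cc2-c2ccncc2)c1`, giving 65% in this assay

Compound 2 stands highest of the two numbers, its nearest neighbour being compound 1 with a number 3 percentage points higher from compound 1 to compound 2 (within the scatter), so the two cannot be told apart. Compound 3 `COc1cc(Cl)cc(-c2nn(-c3cccc(NC(=O)c4cccc(C(F)(F)F)c4)c3)cc2-c2ccncc2)c1` is not yet measured. It differs from compound 2 in one place: 3-(trifluoromethyl)phenyl in place of (3-(trifluoromethyl)phenyl)amino on a carbonyl carbon. For the measured compounds named here, the only measured step, a number 3 percentage points higher from compound 1 to compound 2 (within the scatter), swapped one aryl group for another on the amide-type nitrogen and left the urea intact, so it does not directly speak to removing the amino link at the carbonyl carbon. Going by the values given here, with no step of the same kind to go on, the expectation for compound 3 rests on compound 2 alone, and the step is estimated to be a number 5 percentage points higher from compound 2 to compound 3 (within the scatter), a small move upward within a wide band. Compound 3 is therefore expected to give 70%, with a range from 50% to 90%.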

Compound 3, a percentage reported as activity, at one concentration (the size of the read-out at that concentration, not a potency): 70%
Compound 3: the middle estimate sits on the measured number at the digits printed; measured number inside the range.
By their numbers in this assay, from the lowest: compounds 1, 2 and 3 (each within the scatter of the next).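

In this assay, taking the nitrogen out of the link on the carbonyl carbon, and with it the amide hydrogen of the urea, gives a number 5 percentage points higher from compound 2 to compound 3 (within the scatter) and so does not separate the urea from the shorter amide. Set against the urea with the 3,4-dichlorophenyl group, the same amide gives a number 8 percentage points higher from compound 1 to compound 3 (within the scatter) and again stays unresolved, so at this one concentration the link at this position can lose its nitrogen with no difference this read-out can detect, and nothing available here offers an explanation for that. Still open, going by these compounds, is whether a carbamate oxygen or a methylene group in that link would also leave this assay unchanged. A single concentration also leaves open whether full dose-response curves would separate these compounds.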